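The source may hold more compounds than are shown below. What is called first, only, known or untested is meant among the compounds shown, and "the series" means these compounds.

Working notes on the series in an ADME assay on HEK293 cells (Homo sapiens) for cytotoxicity, with a stated time of 6 h; a lower number here means that less compound is tolerated, a higher number that more compound is tolerated. Three compounds share one core; compound 1 is `CCCCNc1nc(N)nc2ccc(CCc3ccccn3)cc12`, compound 2 is `CCCCNc1nc(N)nc2cccc(Cl)c12`, compound 3 is `CCCCNc1nc(N)nc2cccc(OCc3ccc(CO)cc3OC)c12`. Compound 1 reaches only the limit of the assay at > 18000 nM, so no number is known for it. Compound 2 gives 100 nM, the lowest of the two numbers in hand, and compound 3 gives 16000 nM, a gap beyond the scatter. Going by the values given here, the one value at the limit is noted as the limit of > 18000 nM in this assay, at which 1 of the 3 values shown sits.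

The step now followed goes from compound 2 to compound 4, which is `CCCCNc1nc(N)nc2cccc(OCc3cccnc3)c12`. The change is (pyridin-3-yl)methoxy in place of chloro on an aromatic carbon. Among the compounds with values here, the two compounds carrying a larger side chain on the core, compound 1 and compound 3, both tolerate far more compound than compound 2, which carries only the chloro group; no measured step isolates this change, so the expectation rests on these three values alone. An upward step, well beyond the scatter, is expected, an 80-fold higher number from compound 2 to compound 4 (1.90 log units; beyond the scatter), because compound 3 with its ether side chain gives 16000 nM. Compound 4 is therefore estimated at 8000 nM, with a range from 1500 nM to 30000 nM.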

Compound 4, half-maximal cytotoxic concentration: > 25000 nM
Compound 4 ended at the assay's limit; the forecaster's own chance of this, stated with the estimate: 30%; middle value at least 3.1-fold (0.49 log units) away from the limit.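

In this assay the series now holds one measured single-place change, (pyridin-3-yl)methoxy in place of chloro on an aromatic carbon, and it gives an at least 250-fold higher number from compound 2 to compound 4 (2.39 log units; beyond the scatter) as a large step, beyond the scatter. The low number of compound 2 is thus tied to this one place: with the rest of the molecule unchanged, the exchange of chloro alone takes the value to the top of the assay's range. The size of the step is only a lower bound, since compound 4 stands at a limit and not at a number: the limit of > 25000 nM in this assay, at which 1 of the 4 values shown sits.

The compounds shown do not separate the contributions of the ether oxygen, the methylene, the aromatic ring and its nitrogen. A small methoxy group, a fluoro group or a dimethylamino group on the same aromatic carbon would bear on that question.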